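The source may report more compounds than this note shows. Statements on the series, on what has been measured and on what is new or still open speak of the compounds shown alone.

Working notes on the series. Within the data shown here, in an ADME assay on MDCK cells (Canis lupus familiaris) for cytotoxicity (on this read-out higher numbers stand for lower toxicity in this test and lower numbers for higher toxicity in this test), compound 1 (`CCN(CC)CN1C(=O)/C(=N/NC(=S)Nc2ccc(OC)cc2)c2ccccc21`) gives 9200 nM, within the scatter of compound 2 (`CCN(CC)CN1C(=O)/C(=N/NC(=S)Nc2ccc(OC)cc2)c2cc(Cl)ccc21`) at 11100 nM, while compound 3 (`CCN(CC)CN1C(=O)/C(=N/NC(=S)Nc2ccc(Cl)cc2)c2cc(Cl)ccc21`) has the lowest number so far (2400 nM).

Compound 4 (`CCN(CC)CN1C(=O)/C(=N/NC(N)=S)c2ccccc21`) has no number yet in this assay and differs from compound 1 as follows: hydrogen in place of 4-methoxyphenyl on an amide-type nitrogen (in short, hydrogen in place of 4-methoxyphenyl on an amide-type nitrogen).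

Two measured steps are at hand. The chloro-for-hydrogen step on the shared core (a 1.2-fold higher number from compound 1 to compound 2 (0.08 log units; within the scatter)) lies within the scatter and says little here. The chloro-for-methoxy step on the aromatic group that compound 4 lacks (a 4.6-fold lower number from compound 2 to compound 3 (0.67 log units; beyond the scatter)) is modest but beyond the scatter, so changes at this end can move the number. No measured compound loses the whole group, so neither the size nor the direction of this change is shown directly. Among the measured compounds shown here, with the lower number of compound 3 (2400 nM) as the only guide, a modest rise is expected, held loosely. The estimated step is a modest one (a 2.2-fold higher number from compound 1 to compound 4 (0.34 log units; beyond the scatter)) on this read-out. For compound 4 the estimated value is 20000 nM with an expected range from 7000 nM to 60000 nM in this test.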

Compound 4, half-maximal cytotoxic concentration: 85800 nM
Beside the measured number, compound 4's estimate is 4.3-fold (0.63 log units) below it; measured number above the stated range.
By their numbers in this assay, from the lowest: compound 3; then compounds 1 and 2 (each within the scatter of the next); then compound 4.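

In this assay, taking the entire 4-methoxyphenyl group off the amide-type nitrogen, so that (4-methoxyphenyl)amino becomes amino, gives a 9.3-fold higher number from compound 1 to compound 4 (0.97 log units; beyond the scatter) and thus moves the number towards lower toxicity in this test. Among these compounds, the earlier steps changed only a substituent while an aromatic group stayed on this nitrogen, and the one step beyond the scatter, a 4.6-fold lower number from compound 2 to compound 3 (0.67 log units; beyond the scatter), went the other way; this result adds that the nitrogen can carry no aromatic group at all and the number still rises, with a step beyond the scatter. No measurement in hand bears on why the number moves at this position, and the step stands as an observation only.

The compounds shown leave open how the number behaves between the two extremes, since a methyl, a benzyl or an unsubstituted phenyl on this nitrogen is not among them, and the loss of the methoxy cannot be told apart from the loss of the ring. Also open, from the compounds shown here alone, is whether the same removal gives a step of similar size on the chloro-bearing core of compound 2.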